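A few compounds are considered here, and "the series" means these few. Any claim that something is new, unique, unknown or untested is made for them only; others in the source may bear on it.

Measured compounds, cytotoxicity on Huh-7 cells:

compound 1, `Cc1ccc(S(=O)(=O)N2CCC3(CC2)OOC2(CCCC2)OO3)cc1`: > 100 ug/mL
compound 2, `Cc1ccc(S(=O)(=O)N2CCC3(CC2)OOC2(CCCCCC2)OO3)cc1`: > 100 ug/mL
compound 3, `COc1ccc(S(=O)(=O)N2CCC3(CC2)OOC2(CCCC2)OO3)cc1`: > 100 ug/mL

Three compounds of the series have so far been run in a functional assay on Huh-7 cells (Homo sapiens) for cytotoxicity, read by MTT assay, with a stated time of 72 h; a higher number here means that more compound is tolerated, a lower number that less compound is tolerated. Compound 1 gives > 100 ug/mL, which is a limit of the assay and not a number. Compound 2 gives > 100 ug/mL, again only a limit. Compound 3 likewise gives > 100 ug/mL, a limit as well. None of the three has a measured midpoint, and all three sit at the same boundary, as summed up in the limit of > 100 ug/mL in this assay, at which 3 of the 3 values shown sit.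

Compound 1 and compound 3 differ in one place: methoxy in place of methyl on an aromatic carbon. Because both values are limits, the step that the two limits leave unreadable from compound 1 to compound 3 and its size cannot be read. Compound 1 and compound 2 differ in their cores; that difference is not broken down here.

The unmeasured compound 4, `COc1ccc(S(=O)(=O)N2CCC3(CC2)OOC2(CCCCCC2)OO3)cc1`, stands to compound 2 as compound 3 stands to compound 1: methoxy in place of methyl on an aromatic carbon. The place of the change is the same as before, word for word, so this is the same change made on the other core.

The expectation for compound 4 in this assay is that it stays at the boundary like the three measured compounds, which rests on (the limit of > 100 ug/mL in this assay, at which 3 of the 3 values shown sit). Compound 4 is estimated at 150 ug/mL, with a plausible range from 70 ug/mL to 400 ug/mL. Against compound 2 this expected step is a step that the limit leaves unreadable from compound 2 to compound 4, essentially no readable step, and most likely the assay will again report only a limit.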

Compound 4, half-maximal cytotoxic concentration: > 100 ug/mL
Compound 4: no number, only a limit; the forecaster's own chance of this, stated with the estimate: 85%; the middle value does not contradict the limit.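

In this assay compound 4 gives > 100 ug/mL, which is a limit of the assay and not a number. Compound 2 also stands at a limit, and no step can be read between compound 2 and compound 4. The series stays at one boundary: the limit of > 100 ug/mL in this assay, at which 4 of the 4 values shown sit. The compounds shown leave open where the half-maximal cytotoxic concentration of each one lies, and whether methoxy in place of methyl shifts it on either core.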